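This account rests on a few compounds, and the source may have more. Where it says the series, first, only, none or still open, it means among the compounds named here.

Working notes on the series in a functional assay on HeLa cells (Homo sapiens) for cytotoxicity, read by XTT assay, with a stated time of 24 h; a higher number here means a weaker inhibitor, a lower number a stronger inhibitor: compound 1 (`Cc1cc(Cl)c2c(c1O)C(=O)C=CC2=O`) gives 10100 nM, compound 3 (`CC(=O)Oc1cc(OC(C)=O)c2c(OC(C)=O)cc(C)cc2c1OC(C)=O`) gives 22400 nM, and compound 2 (`CC(=O)Oc1cc(C)c(Cl)c2c1C(=O)C=CC2=O`) gives 26200 nM. Compound 2 therefore stands level with compound 3 within the scatter, and beyond the scatter from compound 1, whose number is lower. Next comes compound 4 (`CCOc1cc(C)c(Cl)c2c1C(=O)C=CC2=O`), which differs from compound 2 in one place: ethyl in place of acetyl on an oxygen on an aromatic ring. In words, this is ethyl in place of acetyl on an oxygen on an aromatic ring, or acetoxy to ethoxy. Going by the values given here, no measured pair isolates this change, so the only guide is the span of the three values, with compound 1 at its low end at 10100 nM. A small drop in this assay, possibly none beyond the scatter, is expected. The estimated change is a 1.4-fold lower number from compound 2 to compound 4 (0.14 log units; within the scatter). The expected value for compound 4 is 19000 nM, with an estimated range of 8000 nM to 45000 nM.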

Compound 4, half-maximal inhibitory concentration: 19000 nM
Beside the measured number, compound 4's estimate shows no gap at the digits printed, and the stated range covers the measured number.
By their numbers in this assay, from the lowest: compounds 1, 4, 3 and 2 (each within the scatter of the next, the first and the last beyond it).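

In this assay, the series now has its first reading of a single change, a 1.4-fold lower number from compound 2 to compound 4 (0.14 log units; within the scatter). On this oxygen on an aromatic ring, ethyl can thus take the place of acetyl without a shift beyond the scatter, so the acetyl carbonyl is not needed to hold a number in this range. No evidence at hand accounts for this result.

Going by these compounds, whether a longer chain on this oxygen, or an amine or carboxylic acid carried on such a chain, would stay within the scatter of compound 2 remains open.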